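Working notes: from hydroxylated chain to ethoxy on carbonyl

The source may report more compounds than this note shows. Statements on the series, on what has been measured and on what is new or still open speak of the compounds shown alone.

Measured in a functional assay on HCT-116 cells (Homo sapiens); a lower number here means a stronger inhibitor, a higher number a weaker inhibitor:
- compound 1 (`COc1cc(NC(C)CCCNC(=O)NCCO)c2ncccc2c1`): > 100000 nM (limit)
- compound 2 (`COc1cc(NC(C)CCCNC(=O)NC(CO)(CO)CO)c2ncccc2c1`): > 100000 nM (limit)

Compound 2 stands only at a limit, > 100000 nM, and has no numerical value. The next compound to be tested is compound 3 (`CCOC(=O)NCCCC(C)Nc1cc(OC)cc2cccnc12`). The change is ethoxy in place of (2-hydroxy-1,1-bis(hydroxymethyl)ethyl)amino on a carbonyl carbon, so ethoxy replaces (2-hydroxy-1,1-bis(hydroxymethyl)ethyl)amino on a carbonyl carbon.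

Within the data shown here, the single measured step is a step that the two limits leave unreadable from compound 1 to compound 2. It has no readable size, and it lies on an amide-type nitrogen rather than on the carbonyl carbon. Among the measured compounds shown here, the only other guide is the limit of > 100000 nM in this assay, at which 2 of the 2 values shown sit, so no measured step sets the size of this one. In this assay a modest step toward stronger inhibition is expected, though this expectation is weakly grounded, and another result at the limit is about as likely as a number.

For compound 3 the estimate is 60000 nM, with an expected range from 15000 nM to 100000 nM. The expected step is an at least 1.6-fold lower number from compound 2 to compound 3 (0.22 log units; that floor lies within the scatter).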

Compound 3, half-maximal inhibitory concentration: 28000 nM
Compound 3: middle estimate off by 2.1-fold (0.33 log units), on the high side, and the stated range covers the measured number.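

In this assay, among these compounds, compound 3 gives 28000 nM as the first readable number, so the group on the carbonyl carbon can bring this read-out to a readable number. Ethoxy in place of the substituted amino group reads as an at least 3.5-fold lower number from compound 2 to compound 3 (0.55 log units; beyond the scatter) and as an at least 3.5-fold lower number from compound 1 to compound 3 (0.55 log units; beyond the scatter) and both sizes are floors, each starting from a limit, so the true gaps may be larger. The step between compound 1 and compound 2 cannot be read, which leaves the change on the amide-type nitrogen without a size, and most of the series still sits at the ceiling of this read-out: the limit of > 100000 nM in this assay, at which 2 of the 3 values shown sit.

Ethoxy replaces the whole amino group in a single change, so the compounds shown do not separate the loss of the amino nitrogen from the loss of the hydroxyl groups. As far as these compounds go, whether a plain ethylamino group on the same carbonyl carbon would also leave the limit, or a longer chain such as butoxy would lower the number further, remains open.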